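Hydroxy gives way to methyl(propyl)amino in a cytotoxicity series

This account rests on a few compounds, and the source may have more. Where it says the series, first, only, none or still open, it means among the compounds named here.

Within the data shown here, in a functional assay on cells (Homo sapiens) for cytotoxicity, read by MTT assay, with a stated time of 48 h (a higher number here means a weaker inhibitor, a lower number a stronger inhibitor), compound 1 (`CN(CC(=O)Nc1cc(O)ccc1O)c1ccccc1`) gives 6000 nM and compound 2 (`O=C(CO)Nc1cc(O)ccc1O`) gives 12000 nM so compound 2 stands within the scatter of the only other number available. Compound 3 (`CCCN(C)CC(=O)Nc1cc(O)ccc1O`) carries methyl(propyl)amino in place of hydroxy on a saturated chain carbon bound to a carbonyl carbon. The expectation rests on compound 1 (6000 nM) which also carries an amino group on that carbon. A small step of a 1.7-fold lower number from compound 2 to compound 3 (0.23 log units; within the scatter) is expected, toward a lower number but not beyond the scatter. In this assay the estimate for compound 3 is 7000 nM with an expected range from 2500 nM to 20000 nM around it.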

Compound 3, half-maximal inhibitory concentration: 18000 nM
For compound 3 the middle estimate is 2.6-fold (0.41 log units) below the measured one, and the stated range covers the measured number.
By their numbers in this assay, from the lowest: compounds 1, 2 and 3 (each within the scatter of the next, the first and the last beyond it).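

In this assay, methyl(propyl)amino in place of hydroxy on a saturated chain carbon bound to a carbonyl carbon gives a 1.5-fold higher number from compound 2 to compound 3 (0.18 log units; within the scatter), so this exchange alone leaves no readable difference. The group on an amine nitrogen does register, with propyl in place of phenyl giving a 3.0-fold higher number from compound 1 to compound 3 (0.48 log units; beyond the scatter). Nothing measured here accounts for that step. The compounds shown leave open how a benzyl or cyclohexyl group on the amine nitrogen would read, and whether a primary amine on the chain carbon would stand with compound 1 or compound 3.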